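The compounds below may be only part of what the source reports. "The series", "measured", "known", "first", "only" and "open" are said of these compounds alone.

Compound 1 `CCCCN1C(=O)CN(S(=O)(=O)c2ccc(-n3nc(C)cc3C)cc2)C1=S` is tested in a functional assay on the whole organism (blood, strain albino) with Mus musculus as the target, with stated times of 6 days and 4 h, at a dose of 1 mmol/kg by the oral route (a higher number here means more inhibition at the dose given (going by the name of the read-out), a lower number less inhibition), where compound 1 gives 1%. Compound 2 `CCCN1C(=O)CN(S(=O)(=O)c2ccc(-n3nc(C)cc3C)cc2)C1=S` differs from it only by hydrogen in place of methyl on a saturated chain carbon, three bonds along the chain from an amide-type nitrogen in a ring. In this assay compound 2 gives < 1%, which is a limit of the assay rather than a number. The step of a number no higher from compound 1 to compound 2 (the limit leaves the size open) has no readable size, since the limit of < 1% in this assay, at which 1 of the 2 values shown sits, is all that is known of compound 2. Compound 3 `Cc1cc(C)n(-c2ccc(S(=O)(=O)N3CC(=O)N(c4ccccc4)C3=S)cc2)n1` carries the change (phenyl in place of propyl on an amide-type nitrogen in a ring). Among the measured compounds shown here, the single measured step alters a chain at that amide-type nitrogen in a ring without a readable size, so little guidance exists; both measured values sit low, and no step beyond the scatter is expected. The expected step is a number at least 2 percentage points higher from compound 2 to compound 3 (that floor lies within the scatter). Compound 3 is estimated at 3%, with a range from 0% to 15%.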

Compound 3, a percentage reported as inhibition, in the whole organism at one dose (the size of the read-out at that dose, not a potency): 8%
For compound 3 the middle estimate is 5 percentage points below the measured one, and the stated range covers the measured number.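

Replacing the propyl chain on the amide-type nitrogen in a ring with phenyl, a six-membered aromatic ring of carbon only, gives in this assay a number at least 7 percentage points higher from compound 2 to compound 3 (that floor lies within the scatter). Replacing butyl with phenyl at the same place gives a number 7 percentage points higher from compound 1 to compound 3 (within the scatter), so a ring at this position gives no result that can be told apart from a saturated chain. The comparison with compound 2 also has an open size, since its reading is a limit of the assay and not a number: the limit of < 1% in this assay, at which 1 of the 3 values shown sits.

As far as these compounds go, it remains open whether any group at this position can raise inhibition clearly beyond the scatter. The compounds shown do not tell how a benzyl group, a phenyl ring carrying a chlorine atom, or a chain ending in an amine would read here.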